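Exchanging a pyridinyl group on a shared carbonyl carbon

The source may report more compounds than this note shows. Statements on the series, on what has been measured and on what is new or still open speak of the compounds shown alone.

The set comprises compound 1 `COc1ccc(C2=NN(C(=O)c3cncc(Br)c3)C(c3ccc(Cl)cc3)C2)cc1`, compound 2 `COc1ccc(C2=NN(C(=O)c3ccc(Cl)nc3)C(c3ccc(Cl)cc3)C2)cc1`, compound 3 `O=C(c1cncc(Br)c1)N1N=C(c2ccc(Cl)cc2)CC1c1ccc(Br)cc1` and the still unmeasured compound 4 `O=C(c1ccc(Cl)nc1)N1N=C(c2ccc(Cl)cc2)CC1c1ccc(Br)cc1`. In a functional assay on WM 266-4 cells (Homo sapiens) for antiproliferative activity, read by MTT assay, with a stated time of 24 h (a lower number here means a stronger inhibitor of growth, a higher number a weaker inhibitor of growth), compound 1 gives 1290 nM, and compound 2 gives 1450 nM. The change 6-chloropyridin-3-yl in place of 5-bromopyridin-3-yl on a carbonyl carbon produced a 1.1-fold higher number from compound 1 to compound 2 (0.05 log units; within the scatter). Compound 3 gives 8010 nM in this assay, the highest number of the three measured; how its core differs from the core of compound 1 is not broken down here. Compound 4 carries the same change relative to compound 3, (6-chloropyridin-3-yl in place of 5-bromopyridin-3-yl on a carbonyl carbon), at a place described in exactly the same words, so it is the same change made on a different core. Compound 4 is therefore expected to show a step of a 1.1-fold higher number from compound 3 to compound 4 (0.04 log units; within the scatter) because the same exchange gave a 1.1-fold higher number from compound 1 to compound 2 (0.05 log units; within the scatter). Compound 4 is estimated at 8800 nM in this assay, with a likely range from 4500 nM to 17000 nM.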

Compound 4, concentration for 50% growth inhibition: 9870 nM
Compound 4: middle estimate off by 1.1-fold (0.05 log units), on the low side; the measured number falls inside the stated range.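

In this assay, placing 6-chloropyridin-3-yl where 5-bromopyridin-3-yl stood on the carbonyl carbon gave a 1.2-fold higher number from compound 3 to compound 4 (0.09 log units; within the scatter). Set beside the earlier step, the exchange reads the same on both cores: the same change on two cores in this assay, a 1.1-fold higher number (0.05 log units; within the scatter) from compound 1 to compound 2 and a 1.2-fold higher number (0.09 log units; within the scatter) from compound 3 to compound 4, 1.1-fold (0.04 log units) apart, within the scatter of two such steps

So in this series, the near-absence of an effect carried over from the core of compound 1 to the core of compound 3; this does not show that a change with a large effect would carry over in the same way, nor that the result would hold on any core beyond these two.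

The compounds shown leave open whether a different group on the same carbonyl carbon, such as a pyridinyl ring bearing an amine or a carboxylic acid, would shift the number beyond the scatter. Compound 1 and compound 3 also differ in more than one place, so no single part of the core can be credited with the gap between their values.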